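The source may hold more compounds than are shown below. What is called first, only, known or untested is meant among the compounds shown, and "the series" means these compounds.

Working notes on the adenosine series.

Of the compounds shown here, three of the shared core have been measured in an assay on CHO-K1 cells for displacement of a labelled ligand from adenosine receptor A1 (Homo sapiens), read by scintillation counting, with a stated time of 60 min; on this read-out lower numbers stand for stronger inhibition and higher numbers for weaker inhibition. Compound 1 `N#Cc1ccc(/C=N/Nc2nc(N)c3ncn([C@@H]4O[C@H](CO)[C@@H](O)[C@H]4O)c3n2)cc1` gives 4.1 nM and compound 2 `Nc1nc(N/N=C/c2ccc(N3CCCC3)cc2)nc2c1ncn2[C@@H]1O[C@H](CO)[C@@H](O)[C@H]1O` gives 5.1 nM; the step between them, a 1.2-fold higher number from compound 1 to compound 2 (0.09 log units; within the scatter), is small. Compound 3 `CCCCc1nc(/C=N/Nc2nc(N)c3ncn([C@@H]4O[C@H](CO)[C@@H](O)[C@H]4O)c3n2)c(Cl)[nH]1` gives 12 nM and stands at the highest number of the three: the two steps leading to it, a 2.9-fold higher number from compound 1 to compound 3 (0.47 log units; beyond the scatter) and a 2.4-fold higher number from compound 2 to compound 3 (0.37 log units; beyond the scatter), are both modest but beyond the scatter, so exchanging the six-membered aromatic ring of compound 1 or compound 2 for the imidazolyl group of compound 3 costs some affinity in this assay.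

Compound 4 `Nc1nc(N/N=C/c2ccc(Br)cn2)nc2c1ncn2[C@@H]1O[C@H](CO)[C@@H](O)[C@H]1O` is not yet measured. Its difference from compound 3 is 5-bromopyridin-2-yl in place of 2-butyl-5-chloro-1H-imidazol-4-yl on a carbon with a double bond to nitrogen. This returns a six-membered aromatic ring to the carbon with a double bond to nitrogen, as in compound 1 and compound 2, so the two steps that bear on it are a 2.9-fold higher number from compound 1 to compound 3 (0.47 log units; beyond the scatter) and a 2.4-fold higher number from compound 2 to compound 3 (0.37 log units; beyond the scatter), read in reverse. The expectation is therefore a step in the direction of a lower number, comparable in size to those two, rather than no change. Compound 4 is thus estimated at 5 nM, with a range of 2 nM to 12 nM, which means an expected step of a 2.4-fold lower number from compound 3 to compound 4 (0.38 log units; beyond the scatter).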

Compound 4, inhibition constant: 4.7 nM
The estimate for compound 4 lay 1.1-fold (0.03 log units) above the measured number; measured number inside the range.
By their numbers in this assay, from the lowest: compounds 1, 4 and 2 (each within the scatter of the next); then compound 3.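

In this assay, the step of a 2.6-fold lower number from compound 3 to compound 4 (0.41 log units; beyond the scatter) shows that the cost seen with 2-butyl-5-chloro-1H-imidazol-4-yl is not kept when 5-bromopyridin-2-yl stands on the carbon with a double bond to nitrogen, and that a six-membered aromatic ring with a hetero atom serves here as well as the two substituted phenyl rings measured before. The steps of a 1.1-fold lower number from compound 2 to compound 4 (0.04 log units; within the scatter) and a 1.1-fold higher number from compound 1 to compound 4 (0.06 log units; within the scatter) both lie within the scatter, so 5-bromopyridin-2-yl, 4-cyanophenyl and 4-(pyrrolidin-1-yl)phenyl cannot be told apart at this position, and among these four compounds only compound 3, the one with a five-membered ring, stands apart. No measured evidence bears on the reason for this result.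

The step from compound 3 to compound 4 changes the ring, the butyl chain, the halogen and the ring hydrogen-bond donor at once, so the compounds shown cannot assign it to any one of these. An imidazolyl group without the butyl chain, or a pyridinyl group carrying a carboxylic acid or a primary amine in place of bromine, would show how far this tolerance extends.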